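The compounds below may be only part of what the source reports. "The series", "measured", "known", "first", "only" and "open" are said of these compounds alone.

Compound 3 `COc1cc(-c2nn(-c3cccc(NC(=O)Nc4cccc(C(F)(F)F)c4)c3)cc2-c2ccncc2)ccc1Cl` has been measured in a functional assay on TK-10 cells (Homo sapiens) for inhibition, read by sulforhodamine B assay, with a stated time of 48 h; a higher number here means that more compound is tolerated, a lower number that less compound is tolerated. There, compound 3 gives > 50000 nM, which is a limit and not a number. Compound 2 `COc1cc(-c2nn(-c3cccc(NC(=O)Nc4ccc(Cl)c(Cl)c4)c3)cc2-c2ccncc2)ccc1Cl` gives > 50000 nM, also a limit. Compound 1 `O=C(Nc1cccc(-n2cc(-c3ccncc3)c(-c3ccc(Cl)c(O)c3)n2)c1)Nc1cccc(C(F)(F)F)c1` gives > 32500 nM, again a limit. Compound 3 therefore has no exact place on the scale.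

Compound 4 `COc1cc(-c2nn(-c3cccc(NC(=O)Nc4ccc(Cl)c(C(F)(F)F)c4)c3)cc2-c2ccncc2)ccc1Cl` differs from compound 3 by a single change: chloro in place of hydrogen on an aromatic carbon. Chloro takes the place of hydrogen on an aromatic carbon, so 3-(trifluoromethyl)phenyl becomes 4-chloro-3-(trifluoromethyl)phenyl.

The closest measured change is a step that the two limits leave unreadable from compound 2 to compound 3, where 3-(trifluoromethyl)phenyl replaces 3,4-dichlorophenyl on an amide-type nitrogen. The other is a step that the two limits leave unreadable from compound 1 to compound 3, where methyl replaces hydrogen on an oxygen on an aromatic ring. Neither has a readable size, so neither gives a size or direction to carry over. No step beyond the usual scatter is expected in this assay, and another limit is the likeliest result. The expected step is a number no higher from compound 3 to compound 4 (the limit leaves the size open). The estimate for compound 4 is 50000 nM, with an expected range of 25000 nM to 100000 nM.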

Compound 4, concentration lethal to 50% of the cells: > 32500 nM
Compound 4: only a limit was reported; the forecaster's own chance of this, stated with the estimate: 75%; the middle value is on the limit's open side.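

For the compounds shown here, compound 4 gives only a limit in this assay, as do compound 2 and compound 3, so no step to compound 4 can be read. The compounds shown leave open the actual lethal concentration of each compound, and whether chloro in place of hydrogen changes it at all.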